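The source may report more compounds than this note shows. Statements on the series, on what has been measured and on what is new or still open speak of the compounds shown alone.

Measured in an ADME assay on CEM-SS cells (Homo sapiens) for cytotoxicity, read by XTT assay, with a stated time of 6 days; a higher number here means that more compound is tolerated, a lower number that less compound is tolerated:
- compound 1 `CCCC(=O)OCSc1ccccc1C(=O)NCC(N)=O`: > 100 uM, a limit of the assay and not a number
- compound 2 `CCCC(=O)OCSc1ccccc1C(=O)OCC(N)=O`: 82.1 uM
- compound 3 `CCCC(=O)OCSc1ccccc1C(=O)NCC(=O)OC`: 27.3 uM

Compound 3 has the lowest number of the three in this assay, so it is the least tolerated of this set. The next compound, compound 4 `CCCC(=O)OCSc1ccccc1C(=O)N(C)CC(N)=O`, carries (carbamoylmethyl)(methyl)amino in place of ((methoxycarbonyl)methyl)amino on a carbonyl carbon.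

Within the data shown here, two measured steps bear on this change. Compound 1 and compound 2 both hold the carbamoyl part that enters in compound 4, while compound 3 holds methoxycarbonyl instead. The comparisons show an at least 3.6-fold lower number from compound 1 to compound 3 (0.56 log units; beyond the scatter) and a 3.0-fold lower number from compound 2 to compound 3 (0.48 log units; beyond the scatter). Neither compound goes against this small pattern, although three compounds are a thin basis. Among the measured compounds shown here, no measured step here isolates the added methyl, so this part of the change remains an open question.

A step back up of similar size is therefore expected, which would be a 3.1-fold higher number from compound 3 to compound 4 (0.49 log units; beyond the scatter). The result could also be only a limit, and this possibility is set by the limit of > 100 uM in this assay, at which 1 of the 3 values shown sits. For compound 4 the expected value is 85 uM, with an estimated range of 40 uM to 180 uM.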

Compound 4, half-maximal toxic concentration: 55.3 uM
The estimate for compound 4 lay 1.5-fold (0.19 log units) above the measured number, within the range that was stated.
By their numbers in this assay, from the lowest: compound 3; then compounds 4 and 2 (each within the scatter of the next). At a limit, above all of these: compound 1.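

In this assay, replacing ((methoxycarbonyl)methyl)amino with (carbamoylmethyl)(methyl)amino on a carbonyl carbon gives a real rise (a 2.0-fold higher number from compound 3 to compound 4 (0.31 log units; beyond the scatter)), so a carbamoyl-bearing compound again sits clear of the methoxycarbonyl compound, even with an added methyl. Compound 4 also cannot be separated from the ester-linked carbamoyl compound (a 1.5-fold lower number from compound 2 to compound 4 (0.17 log units; within the scatter)), so at this position the (carbamoylmethyl)(methyl)amino and carbamoylmethoxy groups are not told apart in this assay. From the compounds shown here alone, the added methyl can now be looked at on its own as methyl in place of hydrogen on an amide-type nitrogen (an at least 1.8-fold lower number from compound 1 to compound 4 (0.25 log units; that floor lies within the scatter)), but this step is only a floor, and its true size stays unknown since the value for compound 1 is a limit of the assay and not a number: the limit of > 100 uM in this assay, at which 1 of the 4 values shown sits.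

The compounds shown leave open whether a carboxylic acid in place of the methoxycarbonyl part would be tolerated more or less than the methyl ester or the carbamoyl group. They also leave open how an ethyl group in place of the methyl on the amide-type nitrogen, or a longer chain in the ester on the shared core, would shift the number.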